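Adding hydroxymethyl to a compound at the assay limit

The source may hold more compounds than are shown below. What is called first, only, known or untested is meant among the compounds shown, and "the series" means these compounds.

Compound 2 `O[C@H]1CO[C@H](COCc2ccccc2)[C@@H](OCc2ccccc2)[C@@H]1OCc1ccccc1` has no exact number in a functional assay on HeLa cells (Homo sapiens) for antiproliferative activity, read by sulforhodamine B assay (on this read-out higher numbers stand for weaker inhibition of growth and lower numbers for stronger inhibition of growth), only a limit of > 50000 nM. Compound 1 `c1ccc(COC[C@H]2OCC[C@@H](OCc3ccccc3)[C@@H]2OCc2ccccc2)cc1` gives 33300 nM, and compound 3 `CC(C)C[C@H]1O[C@H](COCc2ccccc2)[C@@H](OCc2ccccc2)[C@H](OCc2ccccc2)[C@H]1O` gives 43900 nM. Compound 4 `OC[C@@H]1O[C@H](COCc2ccccc2)[C@@H](OCc2ccccc2)[C@H](OCc2ccccc2)[C@H]1O` comes from compound 2 by hydroxymethyl in place of hydrogen on a saturated ring carbon. For the measured compounds named here, two measured steps bear on this change. Hydroxy in place of hydrogen gave an at least 1.5-fold higher number from compound 1 to compound 2 (0.17 log units; that floor lies within the scatter), and isobutyl in place of hydrogen gave an at least 1.1-fold lower number from compound 2 to compound 3 (0.05 log units; that floor lies within the scatter). Both are only floors within the scatter, so no step beyond the scatter is expected in this assay, and the expected step is an at least 1.1-fold lower number from compound 2 to compound 4 (0.04 log units; that floor lies within the scatter). For compound 4 the estimate is 45000 nM, with an expected range of 22000 nM to 90000 nM.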

Compound 4, concentration for 50% growth inhibition: 25800 nM
The estimate for compound 4 lay 1.7-fold (0.24 log units) above the measured number, and the stated range covers the measured number.
By their numbers in this assay, from the lowest: compounds 4, 1 and 3 (each within the scatter of the next). At a limit, above all of these: compound 2.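

In this assay, hydroxymethyl next to the ring oxygen gives an at least 1.9-fold lower number from compound 2 to compound 4 (0.28 log units; that floor lies within the scatter). Only a floor can be read because compound 2 stands at a limit: the limit of > 50000 nM in this assay, at which 1 of the 4 values shown sits. At this position, hydroxymethyl and isobutyl are not told apart, since compound 3 gives 43900 nM and compound 4 gives 25800 nM, values within the scatter of each other. As far as these compounds go, the true size of the step from the hydrogen remains open. So does whether an amine or a carboxylic acid on this ring carbon would move the number beyond the scatter.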